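The source may report more compounds than this note shows. Statements on the series, on what has been measured and on what is new or still open speak of the compounds shown alone.

Measured so far in an assay on MDA-MB-231 cells for binding affinity to C-X-C chemokine receptor type 4 (Homo sapiens), read by immunofluorescence and microscopy, with stated times of 10 min and 30 min; a higher number here means that more compound is needed for the effect, a lower number that less compound is needed: compound 1 `Cc1ccc(S(=O)(=O)NCc2ccc(CNC(=O)c3ccc(F)cc3)cc2)cc1` gives 1 nM; compound 2 `O=C(NCc1ccc(CNS(=O)(=O)c2ccccc2)cc1)c1ccc(F)cc1` gives 100 nM; compound 3 `O=C(NCc1ccc(CNS(=O)(=O)c2ccccc2)cc1)c1ccccc1F` gives 1000 nM.

Compound 4 `Cc1ccc(S(=O)(=O)NCc2ccc(CNC(=O)c3ccccc3F)cc2)cc1` has not yet been measured in this assay. It differs from compound 3 by one change, (methyl in place of hydrogen on an aromatic carbon). The same change has been seen once before, from compound 2 to compound 1, as methyl in place of hydrogen on an aromatic carbon, where it gave a 100-fold lower number from compound 2 to compound 1 (2.00 log units; beyond the scatter). The place of the change is the same in both pairs, so this is the same change on a different core. The two cores differ by 2-fluorophenyl in place of 4-fluorophenyl on a carbonyl carbon, a change that on its own gave a 10-fold higher number from compound 2 to compound 3 (1.00 log units; beyond the scatter), leaving compound 3 with the highest number of the three. Resting on the single earlier step from compound 2 to compound 1, compound 4 is expected to move in the same direction: a 50-fold lower number from compound 3 to compound 4 (1.70 log units; beyond the scatter). Among the measured compounds shown here, a somewhat smaller step is estimated because a 100-fold lower number from compound 2 to compound 1 (2.00 log units; beyond the scatter) is the only example of this change so far. Compound 4 is therefore estimated at 20 nM, most likely between 3 nM and 150 nM.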

Compound 4, effective concentration (reported as EC, without a stated level of effect): 1000 nM
The estimate for compound 4 lay 50-fold (1.70 log units) below the measured number; measured number outside the range, above it.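

In this assay, adding the methyl to the core of compound 3 gives no change at the digits printed from compound 3 to compound 4 (within the scatter), so the step seen on the core of compound 2 does not carry over: the same change on two cores in this assay, a 100-fold lower number (2.00 log units; beyond the scatter) from compound 2 to compound 1 and no change at the digits printed (within the scatter) from compound 3 to compound 4, 100-fold (2.00 log units) apart, beyond the scatter of two such steps

Swapping 4-fluorophenyl for 2-fluorophenyl with the methyl present gives a 1000-fold higher number from compound 1 to compound 4 (3.00 log units; beyond the scatter), so the two changes do not simply add up: the same change on two cores in this assay, a 10-fold higher number (1.00 log units; beyond the scatter) from compound 2 to compound 3 and a 1000-fold higher number (3.00 log units; beyond the scatter) from compound 1 to compound 4, 100-fold (2.00 log units) apart, beyond the scatter of two such steps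

These two pairs show that the effect of the methyl depends on which fluorophenyl group the core carries, but they do not show why, or whether this holds on other cores.

Left open is whether a methoxy group or a chlorine atom in place of the methyl would depend on the fluorophenyl group in the same way.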